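Hydroxy on the Phenyl Ring in Two Bromopyrrole Series

The source may hold more compounds than are shown below. What is called first, only, known or untested is meant among the compounds shown, and "the series" means these compounds.

Potency was read in a functional assay on WRL68 cells (Homo sapiens) for cytotoxicity, read by MTT assay, with stated times of 6 h and 48 h; a higher number here means a weaker inhibitor, a lower number a stronger inhibitor. Compound 1 `O=C(/C=C/c1cc(Br)c(Br)[nH]1)c1ccccc1O` gives 1420 nM in this assay. Compound 2 `O=C(/C=C/c1cc(Br)c(Br)[nH]1)c1ccccc1` reaches only a limit of the assay, >= 100000 nM, in this assay. The change from compound 2 to compound 1 is hydroxy in place of hydrogen on an aromatic carbon and gives an at least 70-fold lower number from compound 2 to compound 1 (1.84 log units; beyond the scatter).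

Compound 3 `Cn1c(-c2cc(-c3ccccc3)no2)cc(Br)c1Br` also reaches only a limit, >= 100000 nM, in this assay. The difference between the core of compound 3 and the core of compound 2 is not broken down here. Compound 4 `Cn1c(-c2cc(-c3ccccc3O)no2)cc(Br)c1Br` carries the same change as compound 1, (hydroxy in place of hydrogen on an aromatic carbon), on the core of compound 3.

Among the measured compounds shown here, two of the three numbers known so far are limits, (the limit of >= 100000 nM in this assay, at which 2 of the 3 values shown sit), so the measured step rests on one pair. Still, the step from compound 3 to compound 4 is expected to be an at least 20-fold lower number from compound 3 to compound 4 (1.30 log units; beyond the scatter), because the same change gave an at least 70-fold lower number from compound 2 to compound 1 (1.84 log units; beyond the scatter). Compound 4 is therefore estimated to give 5000 nM in this assay, with an expected range from 800 nM to 100000 nM.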

Compound 4, half-maximal inhibitory concentration: >= 100000 nM
Compound 4: only a limit was reported; the forecaster's own chance of this, stated with the estimate: 30%; at least 20-fold (1.30 log units) between middle value and limit.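

Compound 3 and compound 4 both stop at a limit of the assay rather than at a number, so no step can be read between them, because neither has a measured value: the limit of >= 100000 nM in this assay, at which 3 of the 4 values shown sit.

The compounds shown leave open whether hydroxy in place of hydrogen on an aromatic carbon changes the number at all on the core of compound 3.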